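A Methyl Step Carried From One Core to Another

The source may hold more compounds than are shown below. What is called first, only, known or untested is meant among the compounds shown, and "the series" means these compounds.

Compound 1 `CCn1ncnc1-c1ccccc1NCC1=NCCN1` and compound 2 `CCCn1ncnc1-c1ccccc1NCC1=NCCN1` were measured in an in vitro functional assay on cells (Fibroblast) for agonist activity at Alpha-1B adrenergic receptor (Homo sapiens); a higher number here means that more compound is needed for the effect, a lower number that less compound is needed. Compound 1 gives 63.1 nM, and compound 2 gives 316 nM. The difference between them is methyl in place of hydrogen on a saturated chain carbon, two bonds along the chain from an aromatic nitrogen, which brought a 5.0-fold higher number from compound 1 to compound 2 (0.70 log units; beyond the scatter).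

Compound 3 `Cn1nccc1-c1ccccc1NCC1=NCCN1` carries a different core; the difference between the two cores is not broken down here. For compound 3 this assay reports only a limit, < 100000 nM, as noted in the limit of < 100000 nM in this assay, at which 1 of the 3 values shown sits.

Compound 4 `CCn1nccc1-c1ccccc1NCC1=NCCN1` differs from compound 3 by methyl in place of hydrogen on a saturated chain carbon bound to an aromatic nitrogen. This is the same kind of change as the one made on the core of compound 1, though the place is not identical: here the carbon is bound to an aromatic nitrogen, whereas before it lay two bonds along the chain from an aromatic nitrogen.

With compound 3 known only through a limit, the step is expected to be a step that the limit leaves unreadable from compound 3 to compound 4, loosely guided by the earlier step of a 5.0-fold higher number from compound 1 to compound 2 (0.70 log units; beyond the scatter). Compound 4 is accordingly expected to give about 5000 nM, within a wide range from 300 nM to 60000 nM.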

Compound 4, half-maximal effective concentration: < 100000 nM
Compound 4 ended at the assay's limit (the forecaster's own chance of this, stated with the estimate: 30%); the middle value is on the limit's open side.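

Compound 3 and compound 4 both stand only as limits in this assay, so no step between them can be read: the limit of < 100000 nM in this assay, at which 2 of the 4 values shown sit.

Going by these compounds, whether the methyl step seen between compound 1 and compound 2 carries over to the core of compound 3 stays open.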